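Trifluoromethyl for Methyl on a Thioether Propargylamine

This account rests on a few compounds, and the source may have more. Where it says the series, first, only, none or still open, it means among the compounds named here.

Compound 1 `C#CCNC1CCc2c(SCc3cccc(C)c3)cccc21`: > 100000 nM
Compound 2 `C#CCNC1CCc2c(OCc3cccc(C(F)(F)F)c3)cccc21`: 6410 nM

In an assay on isolated protein for inhibition of Amine oxidase [flavin-containing] B (Homo sapiens) (on this read-out higher numbers stand for weaker inhibition and lower numbers for stronger inhibition), compound 1 is reported only as a limit, > 100000 nM, and so it stands at the limit of > 100000 nM in this assay, at which 1 of the 2 values shown sits. Compound 2 gives 6410 nM in this assay. Compound 3 `C#CCNC1CCc2c(SCc3cccc(C(F)(F)F)c3)cccc21` carries the change (trifluoromethyl in place of methyl on an aromatic carbon). Among the compounds with values here, no measured pair shows this exact change, so the size of the step is uncertain, and since compound 1 is only a limit its direction can only be toward stronger inhibition or none beyond the scatter. The expected step of an at least 2.0-fold lower number from compound 1 to compound 3 (0.30 log units; that floor lies within the scatter) leans toward stronger inhibition. Compound 3 is estimated at 50000 nM, within 8000 nM to 200000 nM.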

Compound 3, half-maximal inhibitory concentration: 4.7 nM
The estimate for compound 3 lay 11000-fold (4.03 log units) above the measured number; the measured number lies below the stated range.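

With the thioether kept, trifluoromethyl in place of methyl on an aromatic carbon brings, in this assay, an at least 21000-fold lower number from compound 1 to compound 3 (4.32 log units; beyond the scatter). The earlier compounds shown here offered no pair with this change; this one shows that a single substituent at this position can decide the read-out on the shared core. The true size of the step cannot be fixed, as the value of compound 1 is a limit and not a number: the limit of > 100000 nM in this assay, at which 1 of the 3 values shown sits.

On these data alone, it remains open whether this position favours trifluoromethyl alone, or whether a chlorine atom, a nitrile or a methoxy group on the same aromatic carbon would serve as well.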